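Pyridin-3-yl for 4-Chlorophenyl: an Expected Outcome

The compounds below may be only part of what the source reports. "The series", "measured", "known", "first", "only" and "open" are said of these compounds alone.

Compound 1, `Nc1ccccc1NC(=O)c1ccc(CSC(=S)N2CCN(c3ccc(Cl)cc3)CC2)cc1`, was tested in a functional assay on MGC-803 cells (Homo sapiens) for antiproliferative activity, read by CCK-8 assay, with a stated time of 72 h, tested at 8 uM (a higher number here means a stronger effect of the compound at the concentration tested, a lower number a weaker effect), where compound 1 gives 17.2%. For the measured compounds named here, the only other measured member, compound 2, `CN(Cc1ccncc1)C(=S)SCc1ccc(C(=O)Nc2ccccc2N)cc1`, gives 83.2% in this assay, a number far beyond the scatter above the value of compound 1. These two compounds differ in more than one place. Going by the values given here, their numbers show only that compound 1 stands lowest of the two and that compound 2 stands well above it; no single change links them.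

Compound 3, `Nc1ccccc1NC(=O)c1ccc(CSC(=S)N2CCN(c3cccnc3)CC2)cc1`, has not yet been measured in this assay. It departs from compound 1 in one place: pyridin-3-yl in place of 4-chlorophenyl on an amine nitrogen in a ring. The pyridin-3-yl group enters where the 4-chlorophenyl group leaves, on an amine nitrogen in a ring.

No step between measured compounds that differ in one place is available, so the effect of this swap has no precedent among the compounds shown. Compound 1 is expected to move only modestly with this change, by a number 7.8 percentage points higher from compound 1 to compound 3 (within the scatter), a step that may not exceed the scatter. Compound 3 is therefore estimated at 25%, within a range from 8% to 50%.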

Compound 3, a percentage reported as inhibition, at one concentration (the size of the read-out at that concentration, not a potency): 76.9%
Compound 3: middle estimate off by 51.9 percentage points, on the low side, outside the stated range (above it).
By their numbers in this assay, from the lowest: compound 1; then compounds 3 and 2 (each within the scatter of the next).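

The group on the amine nitrogen in the ring proves to be a strong determinant of the read-out: in this assay, pyridin-3-yl in place of 4-chlorophenyl moves the number by a number 59.7 percentage points higher from compound 1 to compound 3 (beyond the scatter). For the compounds shown here, this is the first step that changes a single place, and it shows that the far end of the six-membered ring with two nitrogens is not a position where aromatic groups can be exchanged freely, even though the two groups are close in size and each is a single six-membered aromatic ring. By the count of features, the entering group has a ring nitrogen and a hydrogen-bond acceptor, while the leaving group has a chlorine and no acceptor, but nothing available explains how either difference relates to the step.

This single step changes both features together, so it leaves open whether the gain goes with gaining the ring nitrogen or with losing the chlorine. A plain phenyl group at this place would separate the two, and pyridin-4-yl or pyridin-2-yl would test whether the location of the ring nitrogen matters.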